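Chloro-to-fluoro swap on a sulfonamide aryl ring

The source may hold more compounds than are shown below. What is called first, only, known or untested is meant among the compounds shown, and "the series" means these compounds.

Measured compounds:
compound 1, `C[C@@H]1CN(c2ccc(Cl)c(NS(=O)(=O)c3ccc(-c4ccccn4)s3)c2)C[C@H](C)N1`, 1
compound 2, `C[C@@H]1CN(c2ccc(F)c(NS(=O)(=O)c3ccc(-c4ccccn4)s3)c2)C[C@H](C)N1`, 0.8
compound 3, `COc1ccc(N2C[C@@H](C)N[C@@H](C)C2)cc1NS(=O)(=O)c1ccc(-c2cccs2)cc1Cl`, 0.9

In a functional assay for agonist activity at growth hormone secretagogue receptor type 1 (Homo sapiens), read by FLIPR (a lower number here means a smaller maximal response, a higher number a larger maximal response), compound 1 gives 1 and compound 2 gives 0.8. The change between them, (fluoro in place of chloro on an aromatic carbon), gave a number 0.20 lower from compound 1 to compound 2 (beyond the scatter). Compound 3, `COc1ccc(N2C[C@@H](C)N[C@@H](C)C2)cc1NS(=O)(=O)c1ccc(-c2cccs2)cc1Cl`, gives 0.9 in this assay; the difference between the cores of compound 1 and compound 3 is not broken down here. Compound 4, `COc1ccc(N2C[C@@H](C)N[C@@H](C)C2)cc1NS(=O)(=O)c1ccc(-c2cccs2)cc1F`, is not yet measured. It differs from compound 3 by fluoro in place of chloro on an aromatic carbon, the same kind of change as before, though here the place is meta to a thiophen-2-yl group rather than para to a 3,5-dimethylpiperazin-1-yl group. A step of about a number 0.15 lower from compound 3 to compound 4 (beyond the scatter) is expected, resting on a number 0.20 lower from compound 1 to compound 2 (beyond the scatter). Compound 4 is therefore estimated at 0.75, between 0.55 and 0.95.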

Compound 4, intrinsic activity: the largest response reached, as a fraction of the reference agonist's: 0.9
Compound 4: the middle estimate sits 0.15 below what was measured; the measured number falls inside the stated range.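

In this assay, putting fluoro in place of chloro on the core of compound 3 gave no change at the digits printed from compound 3 to compound 4 (within the scatter). Set beside the earlier step, the same change did not have the same size on the two cores: the same change on two cores in this assay, a number 0.20 lower (beyond the scatter) from compound 1 to compound 2 and no change at the digits printed (within the scatter) from compound 3 to compound 4, 0.20 apart, beyond the scatter of two such steps So the step seen on the core of compound 1 cannot simply be carried over to the core of compound 3, but two pairs do not show whether the gap follows from the cores themselves or from the different place of the swap, nor what a further core would do.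

The compounds shown leave open how the maximal response would move with a methyl or a nitrile at the same place on either core.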